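The source may report more compounds than this note shows. Statements on the series, on what has been measured and on what is new or still open speak of the compounds shown alone.

Measured so far in a functional assay on CHO-K1 cells for antagonist activity at transient receptor potential cation channel subfamily V member 1 (Homo sapiens), read by FLIPR; a lower number here means a stronger inhibitor, a higher number a weaker inhibitor:
compound 1, `CC(C(=O)NCc1ccc(C(F)(F)F)nc1NCc1ccccc1)c1ccc(NS(C)(=O)=O)c(F)c1`, 203 nM
compound 2, `CC(C(=O)NCc1ccc(C(F)(F)F)nc1NCc1ccc(Cl)cc1)c1ccc(NS(C)(=O)=O)c(F)c1`, 414 nM

Going by the values given here, compound 2 holds the higher of the two numbers; the single recorded comparison is a 2.0-fold higher number from compound 1 to compound 2 (0.31 log units; beyond the scatter). Compound 3, `CC(C(=O)NCc1ccc(C(F)(F)F)nc1N1CCC(C)(C)CC1)c1ccc(NS(C)(=O)=O)c(F)c1`, differs from compound 2 in one place: 4,4-dimethylpiperidin-1-yl in place of (4-chlorobenzyl)amino on an aromatic carbon. Among the compounds with values here, no measured step covers an exchange of this kind; the recorded step concerns only the chloro on the benzyl group and offers no direct guide. With nothing comparable to rest on, no shift beyond the scatter is assumed, and a wide range is kept. Compound 3 is accordingly expected near 400 nM, between 120 nM and 1400 nM. This amounts to an expected step of a 1.0-fold lower number from compound 2 to compound 3 (0.01 log units; within the scatter).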

Compound 3, half-maximal inhibitory concentration: 8 nM
Compound 3: middle estimate off by 50-fold (1.70 log units), on the high side; the whole stated range lies above it.
By their numbers in this assay, from the lowest: compound 3; then compound 1; then compound 2.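

In this assay, the group next to the ring nitrogen has a far larger effect than the chloro on the benzyl group: 4,4-dimethylpiperidin-1-yl gives a 52-fold lower number from compound 2 to compound 3 (1.71 log units; beyond the scatter) and also a 25-fold lower number from compound 1 to compound 3 (1.40 log units; beyond the scatter), a gain that holds with or without that chloro. The exchange removes the carbon-only aromatic ring and the hydrogen-bond donor together, and these compounds do not separate the two. No measurement here accounts for the gain. Open, from the compounds shown here alone, is whether an unsubstituted piperidine, a morpholine or an open-chain diethylamino group matches compound 3. Also open, going by these compounds, is whether N-methylbenzylamino, which lacks the donor but keeps the aromatic ring, recovers any of the gain.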